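Extending the azide chain on a GnRH receptor antagonist

The source may report more compounds than this note shows. Statements on the series, on what has been measured and on what is new or still open speak of the compounds shown alone.

Compound 1 `CCNC(=O)Nc1ccc(-c2nc3n(Cc4c(F)cccc4F)cc(C(=O)NCc4cn(CCOCCOCCN=[N+]=[N-])nn4)c(=O)n3c2CN(C)Cc2ccccc2)cc1` gives < 10000 nM in a functional assay on CHO cells for antagonist activity at Gonadotropin-releasing hormone receptor (Homo sapiens), read by a luciferase reporter, with a stated time of 30 min; a lower number here means a stronger inhibitor, a higher number a weaker inhibitor.
Compound 2 `CCNC(=O)Nc1ccc(-c2nc3n(Cc4c(F)cccc4F)cc(C(=O)NCc4cn(CCOCCOCCOCCN=[N+]=[N-])nn4)c(=O)n3c2CN(C)Cc2ccccc2)cc1` gives < 10000 nM in this assay.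

Compound 2 stands only at a limit of this assay, not at a number: the value of compound 2 is < 10000 nM, a limit of the assay. The same holds for compound 1, whose value of < 10000 nM is likewise a limit. Both values sit at the limit of < 10000 nM in this assay, at which 2 of the 2 values shown sit, so the step from compound 1 to compound 2, a step that the two limits leave unreadable from compound 1 to compound 2, cannot be read.

Compound 3 `CCNC(=O)Nc1ccc(-c2nc3n(Cc4c(F)cccc4F)cc(C(=O)NCc4cn(CCOCCOCCOCCOCCN=[N+]=[N-])nn4)c(=O)n3c2CN(C)Cc2ccccc2)cc1` is not yet measured. It differs from compound 2 by 2-azidoethoxy in place of azido on a saturated chain carbon, two bonds along the chain from an oxygen on a saturated carbon. Within the data shown here, the one measured step of the same kind, from compound 1 to compound 2, was a step that the two limits leave unreadable from compound 1 to compound 2, so no direction can be taken from it. Compound 3 is therefore expected to give about 3000 nM, within a range from 300 nM to 10000 nM. This estimate means a step that the limit leaves unreadable from compound 2 to compound 3, expected to stay within the scatter.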

Compound 3, half-maximal inhibitory concentration: < 10000 nM
Compound 3: only a limit was reported; the forecaster's own chance of this, stated with the estimate: 70%; the middle value does not contradict the limit.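

Among these compounds, no step among compound 1, compound 2 and compound 3 can be read, because each value is a limit of the assay and not a number: the limit of < 10000 nM in this assay, at which 3 of the 3 values shown sit.

The compounds shown leave open how strongly each one actually inhibits the receptor, and whether the longer azide chains make any difference.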